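A few compounds are considered here, and "the series" means these few. Any claim that something is new, unique, unknown or untested is made for them only; others in the source may bear on it.

Measured so far in a functional assay on THP-1 cells (Homo sapiens) for inhibition, read by sulforhodamine B assay, with a stated time of 48 h, tested at 50 uM; on this read-out higher numbers stand for more inhibition of growth at the one concentration tested and lower numbers for less inhibition of growth:

compound 1, `COc1ccccc1/C=C/C(=O)/C=C/c1ccc(OCc2cn(CCCCCOc3cc(=O)oc4ccccc34)nn2)c(OC)c1`: 37%
compound 2, `COc1cc(/C=C/C(=O)/C=C/c2cccs2)ccc1OCc1cn(CCCCCOc2cc(=O)oc3ccccc23)nn1`: 34%

Compound 2 gives the lower of the two numbers, but the gap to compound 1 is small: a number 3 percentage points lower from compound 1 to compound 2 (within the scatter). Since that step stays within the scatter, the two compounds cannot be ranked against each other on this read-out.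

Compound 3, `COc1ccc(/C=C/C(=O)/C=C/c2ccc(OCc3cn(CCCCCOc4cc(=O)oc5ccccc45)nn3)c(OC)c2)cc1OC`, has not yet been measured. It differs from compound 2 in one place: 3,4-dimethoxyphenyl in place of thiophen-2-yl on a double-bonded chain carbon bound to a double-bonded chain carbon. Among the compounds with values here, only one measured step bears on this change, the exchange of one aromatic group for another at the same place on the chain, from compound 1 to compound 2, and that step was within the scatter. On that basis no step beyond the scatter is expected from compound 2 to compound 3, in either direction: a number 2 percentage points higher from compound 2 to compound 3 (within the scatter). Compound 3 is therefore estimated to give 36% in this assay, within a range from 22% to 50%.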

Compound 3, percent growth inhibition at one concentration: 47%
Estimate against measurement, compound 3: 11 percentage points below; low and high end bracket the measured number.
By their numbers in this assay, from the lowest: compounds 2, 1 and 3 (each within the scatter of the next, the first and the last beyond it).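

In this assay, this place on the chain now shows a step that can be told from the scatter: swapping thiophen-2-yl for 3,4-dimethoxyphenyl gives a number 13 percentage points higher from compound 2 to compound 3 (beyond the scatter) and so separates two aromatic groups, which the earlier exchange could not do. The 2-methoxyphenyl group of compound 1 is not separated from 3,4-dimethoxyphenyl, since the exchange gives a number 10 percentage points higher from compound 1 to compound 3 (within the scatter) and so leaves those two compounds unranked. Thus only compound 2 and compound 3 differ clearly, and the exchange at this place is not always without consequence for growth inhibition at the one concentration tested. No measurement is available that explains this difference.

The step from compound 2 to compound 3 changes the ring and adds two methoxy groups at once, so the compounds shown cannot say which of these changes matters. A plain phenyl group, a 4-methoxyphenyl group or a phenyl ring carrying an amine or a carboxylic acid at this place would help to pull those contributions apart.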